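A few compounds are considered here, and "the series" means these few. Any claim that something is new, unique, unknown or untested is made for them only; others in the source may bear on it.

Values in a functional assay on HT-29 cells (Homo sapiens) for inhibition, read by sulforhodamine B assay, with a stated time of 72 h; a higher number here means a weaker inhibitor, a lower number a stronger inhibitor:
- compound 1 `CCSc1ccc(C2CC(=O)N2c2cc(OC)c(OC)c(OC)c2)cc1`: 311 nM
- compound 2 `COc1ccc(C2CC(=O)N2c2cc(OC)c(OC)c(OC)c2)cc1`: 65 nM
- compound 3 `C=CC1C(=O)N(c2cc(OC)c(OC)c(OC)c2)C1c1ccc(OCC)cc1`: 97 nM

Compound 3 lies within the scatter of compound 2 and clearly under compound 1 in this assay. Compound 4 `CCOc1ccc(C2CC(=O)N2c2cc(OC)c(OC)c(OC)c2)cc1` arises from compound 3 with hydrogen in place of vinyl on a saturated ring carbon. Going by the values given here, no measured step covers this change. The only one, a 4.8-fold lower number from compound 1 to compound 2 (0.68 log units; beyond the scatter), is modest and concerns methoxy in place of ethylsulfanyl on an aromatic carbon, so it bears only indirectly. Compound 2 also lacks the vinyl and gives 65 nM, so no shift beyond the scatter is expected. The expected step is a 1.1-fold lower number from compound 3 to compound 4 (0.03 log units; within the scatter). For compound 4 the estimated value is 90 nM, with an expected range of 35 nM to 250 nM.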

Compound 4, half-maximal inhibitory concentration: 65 nM
Estimate against measurement, compound 4: 1.4-fold (0.14 log units) above, within the range that was stated.
By their numbers in this assay, from the lowest: compounds 2, 4 and 3 (each within the scatter of the next); then compound 1.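

In this assay, hydrogen in place of vinyl on the saturated ring carbon gives a 1.5-fold lower number from compound 3 to compound 4 (0.17 log units; within the scatter), so the number at this position does not separate the two groups. Methyl in place of hydrogen on the saturated chain carbon bound to an oxygen on an aromatic ring gives no change at the digits printed from compound 2 to compound 4 (within the scatter), whereas ethoxy in place of ethylsulfanyl gives a 4.8-fold lower number from compound 1 to compound 4 (0.68 log units; beyond the scatter), the only new step beyond the scatter. No supporting data explain these steps.

Going by these compounds, whether an amine or a carboxylic acid on the saturated ring carbon would keep the number within the scatter remains open. On these data alone, a longer chain on that oxygen also remains open.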